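Cyclohexyl to 4-methylphenyl on the ring amide nitrogen

This account rests on a few compounds, and the source may have more. Where it says the series, first, only, none or still open, it means among the compounds named here.

Measured compounds:
compound 1 `O=C1COc2ccc(-c3cnc4ccccc4c3)cc2N1C1CCCCC1`: in a functional assay on HeLa cells (Homo sapiens) for antiproliferative activity, read by MTT assay, with a stated time of 72 h (on this read-out higher numbers stand for weaker inhibition and lower numbers for stronger inhibition), compound 1 gives 19700 nM
compound 2 `Cc1ccc(N2C(=O)COc3ccc(-c4cnc5ccccc5c4)cc32)cc1`: in this assay compound 2 gives > 40000 nM, which is a limit of the assay and not a number
compound 3 `O=C1COc2ccc(-c3cccc(NS(=O)(=O)c4ccc(F)cc4)c3)cc2N1C1CCCCC1`: in this assay compound 3 gives 10800 nM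

The one counted change among these is 4-methylphenyl in place of cyclohexyl on an amide-type nitrogen in a ring. It produced an at least 2.0-fold higher number from compound 1 to compound 2 (0.30 log units; that floor lies within the scatter); compound 2 sits at the limit of > 40000 nM in this assay, at which 1 of the 3 values shown sits, so the true size of that step is open at the upper end. The cores of compound 1 and compound 3 differ, but that difference is not broken down here; their two values in this assay lie within the usual scatter of each other, so nothing is read from the pair.

Compound 4 `Cc1ccc(N2C(=O)COc3ccc(-c4cccc(NS(=O)(=O)c5ccc(F)cc5)c4)cc32)cc1` is not yet measured. It carries the same change as compound 2 does relative to compound 1: 4-methylphenyl in place of cyclohexyl on an amide-type nitrogen in a ring. The place lines match word for word, so it is the same change on the core of compound 3.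

Within the data shown here, from compound 3 to compound 4 the step is expected to be a 2.6-fold higher number from compound 3 to compound 4 (0.41 log units; beyond the scatter) because an at least 2.0-fold higher number from compound 1 to compound 2 (0.30 log units; that floor lies within the scatter) is the only measured evidence on this change and points toward a weaker result, with a real chance that compound 4 also ends at a limit. In this assay compound 4 is therefore estimated at 28000 nM, within a range of 12000 nM to 60000 nM.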

Compound 4, half-maximal inhibitory concentration: > 40000 nM
Compound 4: a limit, no number; the forecaster's own chance of this, stated with the estimate: 40%; middle value at least 1.4-fold (0.15 log units) from the limit.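

In this assay, 4-methylphenyl in place of cyclohexyl on the amide-type nitrogen in the ring now has a second reading, on the core of compound 3, and it gives an at least 3.7-fold higher number from compound 3 to compound 4 (0.56 log units; beyond the scatter), so on that core the change clearly moves toward weaker inhibition, and the reading on the core of compound 1 does not point the other way. Compound 4 gives > 40000 nM, which is a limit of the assay and not a number. The two cores thus share a direction, but this rests on two pairs only, and how far the size of the step carries from one core to the other stays unsettled: the same change on two cores in this assay, an at least 2.0-fold higher number (0.30 log units; that floor lies within the scatter) from compound 1 to compound 2 and an at least 3.7-fold higher number (0.56 log units; beyond the scatter) from compound 3 to compound 4; the limit leaves it open whether they differ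

The compounds shown leave open what other groups on this nitrogen would give, such as phenyl without the methyl, a plain methyl, or a longer chain ending in an amine or a carboxylic acid, and so whether the loss follows 4-methylphenyl alone or any aromatic ring there. The true size of both steps also stays open, with the upper end of the read-out reached this often: the limit of > 40000 nM in this assay, at which 2 of the 4 values shown sit.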